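Phenyl in place of trifluoromethoxy: notes on compound 4

This account rests on a few compounds, and the source may have more. Where it says the series, first, only, none or still open, it means among the compounds named here.

- Compound 1 `C[C@@H](/N=c1\c(O)c(O)\c1=N/c1ccc2c[nH]nc2c1)C(C)(C)C`: 4600 nM
- Compound 2 `CC(/N=c1\c(O)c(O)\c1=N/c1ccc(OC(F)(F)F)cc1)C(C)(C)C`: > 30000 nM (a limit)
- Compound 3 `COC(=O)c1ccc(Nc2c(NC(C)C(C)(C)C)c(=O)c2=O)cc1`: > 30000 nM (a limit)

All three compounds were read in a functional assay for inhibition, with Rattus norvegicus as the target; on this read-out higher numbers stand for weaker inhibition and lower numbers for stronger inhibition. Only compound 1 gives a number, 4600 nM. Compound 2 stands at > 30000 nM, which is a limit of the assay and not a number. Compound 3 gives > 30000 nM, which is also a limit. Together these two make up (the limit of > 30000 nM in this assay, at which 2 of the 3 values shown sit).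

Compound 4 `CC(/N=c1\c(O)c(O)\c1=N/c1ccc(-c2ccccc2)cc1)C(C)(C)C` carries phenyl in place of trifluoromethoxy on an aromatic carbon, para to a large group: phenyl in place of trifluoromethoxy on an aromatic carbon. Among the compounds with values here, no measured pair isolates this change, so the expectation rests on compound 2 alone, at > 30000 nM. In this assay, no step beyond the scatter is expected in either direction. The expected result is a number no higher from compound 2 to compound 4 (the limit leaves the size open). For compound 4 the estimated value is 30000 nM, with an expected range of 8000 nM to 100000 nM. A report of only a limit is the more likely outcome.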

Compound 4, half-maximal inhibitory concentration: > 30000 nM
Compound 4: no number, only a limit; the forecaster's own chance of this, stated with the estimate: 70%; the middle value lies on the limit itself.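

No step can be read from compound 2 to compound 4: in this assay each gives only a limit and not a number. The compounds shown leave open whether phenyl in place of trifluoromethoxy on an aromatic carbon shifts inhibition at all, and in which direction.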